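The compounds below may be only part of what the source reports. "The series", "measured", "known", "first", "only" and "open" are said of these compounds alone.

Measured compounds in a functional assay on CHO cells for antagonist activity at prostaglandin E2 receptor EP1 subtype (Homo sapiens), read by FLIPR and calcium flux; on this read-out higher numbers stand for weaker inhibition and lower numbers for stronger inhibition:
- compound 1 `CCc1ccccc1N(Cc1nnc(Cc2ccc(Cl)cc2)o1)S(=O)(=O)c1ccc(C)cc1` gives 316 nM
- compound 2 `Cc1ccc(S(=O)(=O)N(Cc2nnc(Cc3cccc(Cl)c3)o2)c2cccc(Cl)c2C)cc1` gives 2000 nM
- compound 3 `COc1ccc(Nc2nnc(CN(c3cccc(Cl)c3Cl)S(=O)(=O)c3ccc(C(F)(F)F)cc3)o2)cc1` gives 63.1 nM

Compound 1 stands second highest of the three numbers in this assay. Its nearest neighbour is compound 3, whose number is lower by a margin beyond the usual scatter; compound 2 lies furthest, higher by a margin also beyond the scatter. Among the compounds with values here, no pair among the three differs in only one place, so none of these gaps can be tied to a single structural change; compound 3 differs from compound 1 in several parts of the molecule at once.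

Compound 4 `CCc1ccccc1N(Cc1nnc(CNc2ccc(OC)cc2)o1)S(=O)(=O)c1ccc(C)cc1` is not yet measured. It is derived from compound 1 by the change ((4-methoxyphenyl)amino in place of 4-chlorophenyl on a saturated chain carbon bound to an aromatic carbon). The same kind of aromatic amine attached to the shared core appears in compound 3, but there it sits without the intervening chain carbon and next to other changes, so it offers only weak guidance.

Within the data shown here, since the only compound carrying a related group, compound 3, gives 63.1 nM, a modest move toward lower numbers is expected, with a wide range; the estimated step from compound 1 to compound 4 is a 1.4-fold lower number from compound 1 to compound 4 (0.16 log units; within the scatter). Compound 4 is therefore expected to give 220 nM in this assay, within 60 nM to 900 nM.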

Compound 4, inhibition constant: 794 nM
Estimate against measurement, compound 4: 3.6-fold (0.56 log units) below; measured number inside the range.
By their numbers in this assay, from the lowest: compound 3; then compound 1; then compound 4; then compound 2.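

In this assay, within the data shown here, the exchange of 4-chlorobenzyl for ((4-methoxyphenyl)amino)methyl gives the first single-place comparison: a 2.5-fold higher number from compound 1 to compound 4 (0.40 log units; beyond the scatter). The step lies beyond the usual scatter and is modest in size, so this place on the shared core does register a change of substituent, and here the change goes with weaker inhibition. No measurement on hand accounts for the step or shows which part of the exchange carries it.

The exchange alters two things at once, the amino nitrogen on the chain and the ring substituent, 4-chloro giving way to 4-methoxy, so the compounds shown do not separate them; a 4-methoxybenzyl group and a ((4-chlorophenyl)amino)methyl group at this place on the core of compound 1 would each isolate one part. Also open, as far as these compounds go, is whether the step carries over to the other groups on the sulfonamide nitrogen and the sulfonyl ring seen in compound 2 and compound 3, since neither of these forms a single-place pair with compound 1 or compound 4.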